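Trimming a Benzyl Arm Down to a Methyl Group

The source may hold more compounds than are shown below. What is called first, only, known or untested is meant among the compounds shown, and "the series" means these compounds.

Compound 1 `c1ccc(Cc2nnc(-c3c[nH]c4ccccc34)o2)cc1` was examined in a functional assay on DU-145 cells (Homo sapiens) for cytotoxicity, read by MTT assay; a lower number here means a stronger inhibitor, a higher number a weaker inhibitor. In this assay compound 1 gives > 1000000 nM, which is a limit of the assay and not a number. Compound 2 `COc1cc(-c2nnc(-c3c[nH]c4ccccc34)o2)ccc1OCc1ccccc1` shares the same core. In this assay compound 2 gives > 1000000 nM, again a limit rather than a number. Both results sit at the limit of > 1000000 nM in this assay, at which 2 of the 2 values shown sit, so compound 1 stands at the limit, with nothing to set it apart from compound 2. Compound 3 `Cc1nnc(-c2c[nH]c3ccccc23)o1` has not yet been measured. It differs from compound 1 by hydrogen in place of phenyl on a saturated chain carbon bound to an aromatic carbon, in words hydrogen in place of phenyl on a saturated chain carbon bound to an aromatic carbon. For the measured compounds named here, no measured pair covers this change. Compound 1 rests at a limit, and the step that the limit leaves unreadable from compound 1 to compound 3 is accordingly expected to be none beyond the scatter. Compound 3 is therefore expected to give 1500000 nM, within 300000 nM to 10000000 nM, most likely reported only as a limit.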

Compound 3, half-maximal inhibitory concentration: > 1000000 nM
Compound 3 gave a limit, no number; the forecaster's own chance of this, stated with the estimate: 85%; the middle value lies beyond the limit too.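

Compound 1 and compound 3 both rest at a limit rather than a number in this assay, so no size can be read for the change from benzyl to methyl: the limit of > 1000000 nM in this assay, at which 3 of the 3 values shown sit.

The compounds shown leave open which change to the shared core, if any, would give a readable value in this assay.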